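A Chlorine Shift in a Series Held at Limits

The source may report more compounds than this note shows. Statements on the series, on what has been measured and on what is new or still open speak of the compounds shown alone.

Of the compounds shown here, three sharing one core have been tested in a functional assay on K562 cells (Homo sapiens) for cytotoxicity, with a stated time of 72 h (on this read-out higher numbers stand for weaker inhibition and lower numbers for stronger inhibition), and none has yet given a number. Compound 1 `C[C@@H](NC(=O)c1cc(Cl)ccc1O)C(=O)Nc1ccc(Cl)cc1` returns > 20000 nM, which is a limit of the assay. Compound 2 `CC(C)[C@H](NC(=O)c1cc(Cl)ccc1O)C(=O)Nc1ccc(Cl)cc1` returns > 20000 nM, likewise a limit. Compound 3 `CC(C)[C@H](NC(=O)c1ccc(Cl)cc1O)C(=O)Nc1ccc(Cl)c(Cl)c1` returns > 10000 nM, again a limit. Compound 2 therefore has no measured number of its own, and its standing can be told only as the limit of > 20000 nM in this assay, at which 2 of the 3 values shown sit.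

Compound 4 `CC(C)[C@H](NC(=O)c1cc(Cl)ccc1O)C(=O)Nc1cccc(Cl)c1` keeps everything in compound 2 except one group: 3-chlorophenyl in place of 4-chlorophenyl on an amide-type nitrogen. It carries 3-chlorophenyl in place of 4-chlorophenyl on an amide-type nitrogen, so the two have the same atoms, joined differently. Among the measured compounds shown here, no pair of measured compounds shows a change of this kind, so the expectation rests on the limits alone. Compound 2 gives > 20000 nM, and that limit offers no sign of a gain in this assay. The estimated a number no higher from compound 2 to compound 4 (the limit leaves the size open) is expected to stay within the scatter, in neither direction. For compound 4 the estimate is 20000 nM, with an expected range of 9000 nM to 40000 nM, and a report of only a limit is the likeliest outcome.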

Compound 4, half-maximal inhibitory concentration: > 10000 nM
Compound 4 was reported as a limit; the forecaster's own chance of this, stated with the estimate: 85%; the middle value lies beyond the limit too.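

Among the compounds shown here, compound 2 and compound 4 both stand only as limits, so the change from 4-chlorophenyl to 3-chlorophenyl on an amide-type nitrogen gives no step that can be read. The compounds shown leave open whether any member of this series would return an actual number in this assay, and whether that change has any effect there.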